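A few compounds are considered here, and "the series" means these few. Any claim that something is new, unique, unknown or untested is made for them only; others in the source may bear on it.

Compound 1 `CCN(Cc1ccc(C(=O)NO)cc1)c1ncc(-c2ccc(C)cc2)s1`: 10300 nM
Compound 2 `CCCCN(Cc1ccc(C(=O)NO)cc1)c1ncc(-c2ccc(C)cc2)s1`: 6410 nM
Compound 3 `CCCCCCN(Cc1ccc(C(=O)NO)cc1)c1ncc(-c2ccc(C)cc2)s1`: 5270 nM
Compound 4 `Cc1ccc(-c2cnc(N(CCCOc3ccccc3)Cc3ccc(C(=O)NO)cc3)s2)cc1`: not yet measured

In a functional assay on PC-3 cells (Homo sapiens) for antiproliferative activity, read by MTT assay, with a stated time of 48 h (on this read-out lower numbers stand for stronger inhibition of growth and higher numbers for weaker inhibition of growth), compound 3 gives 5270 nM, within the scatter of both compound 1 and compound 2, so the three values set no order. The change to compound 4 is phenoxy in place of propyl on a saturated chain carbon, three bonds along the chain from a nitrogen on an aromatic ring, in words phenoxy in place of propyl on a saturated chain carbon, three bonds along the chain from a nitrogen on an aromatic ring. Within the data shown here, the steps that bear on it are chain extensions: a 1.6-fold lower number from compound 1 to compound 2 (0.21 log units; within the scatter), a 1.2-fold lower number from compound 2 to compound 3 (0.09 log units; within the scatter) and a 2.0-fold lower number from compound 1 to compound 3 (0.29 log units; within the scatter). None of them adds a ring or an oxygen, so the data offer no direct measure of phenoxy. Since a 2.0-fold lower number from compound 1 to compound 3 (0.29 log units; within the scatter) is the largest of these, no step beyond the scatter is expected in this assay, with a slight lean towards a lower number. The expected step is a 1.3-fold lower number from compound 3 to compound 4 (0.12 log units; within the scatter). The estimate for compound 4 is 4000 nM, with an expected range of 1500 nM to 10000 nM.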

Compound 4, concentration for 50% growth inhibition: 17500 nM
Estimate against measurement, compound 4: 4.4-fold (0.64 log units) below; measured number outside the range, above it.
By their numbers in this assay, from the lowest: compounds 3, 2, 1 and 4 (each within the scatter of the next, the first and the last beyond it).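

In this assay, among these compounds, 3-phenoxypropyl in place of hexyl gives the first step at this place that lies beyond the scatter, a 3.3-fold higher number from compound 3 to compound 4 (0.52 log units; beyond the scatter), and the comparison with the butyl chain gives a 2.7-fold higher number from compound 2 to compound 4 (0.44 log units; beyond the scatter); the alkyl chains alone had produced no such step. Against the ethyl chain the change stays unresolved (a 1.7-fold higher number from compound 1 to compound 4 (0.23 log units; within the scatter)), so the added phenoxy separates compound 4 only from the two longer alkyl compounds. Nothing shown gives a reason for this step.

From the compounds shown here alone, whether the step belongs to the oxygen or to the phenyl ring stays open. A phenylbutyl chain or an aminopropyl chain at this place could fall with hexyl in compound 3 or with 3-phenoxypropyl in compound 4.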